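Diphenylpiperidine variants on rabbit aorta: a swap of chain terminus

This account rests on a few compounds, and the source may have more. Where it says the series, first, only, none or still open, it means among the compounds named here.

Of the compounds shown here, three have been measured in a functional assay (aorta) with Oryctolagus cuniculus as the target; on this read-out higher numbers stand for weaker binding and lower numbers for tighter binding. Compound 3 `COc1cc(OCCCN2CCC(C(c3ccc(F)cc3)c3ccc(F)cc3)CC2)ccc1C(C)=O` gives 3.16 nM, the second highest of the three numbers. Compound 1 `COc1cc(C(C)=O)ccc1OCCCN1CCC(C(c2ccc(F)cc2)c2ccc(F)c(F)c2)CC1` gives 1.26 nM, a lower number by a margin beyond the scatter, while compound 2 `COc1cc(C(C)=O)ccc1OCCCN1CCC(C(N)(c2ccc(F)cc2)c2ccc(F)cc2)CC1` gives 31.6 nM, the highest of the three. Going by the values given here, no pair differing in one place has been compared directly. Compound 4 `CN(CCCN1CCC(C(c2ccc(F)cc2)c2ccc(F)cc2)CC1)c1ccccc1` has not yet been measured in this assay; it differs from compound 3 as follows: methyl(phenyl)amino in place of 4-acetyl-3-methoxyphenoxy on a saturated chain carbon, three bonds along the chain from an amine nitrogen in a ring. Among the compounds with values here, with no comparable step available, the author expects the change to raise the number, by a step of a 3.8-fold higher number from compound 3 to compound 4 (0.58 log units; beyond the scatter). Compound 4 is therefore estimated at 12 nM, in a range from 2.5 nM to 60 nM.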

Compound 4, dissociation constant: 2 nM
The estimate for compound 4 lay 6.0-fold (0.78 log units) above the measured number; the measured number lies below the stated range.
By their numbers in this assay, from the lowest: compounds 1, 4 and 3 (each within the scatter of the next, the first and the last beyond it); then compound 2.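

In this assay, putting methyl(phenyl)amino in place of 4-acetyl-3-methoxyphenoxy on a saturated chain carbon, three bonds along the chain from an amine nitrogen in a ring, gives a 1.6-fold lower number from compound 3 to compound 4 (0.20 log units; within the scatter), so the read-out does not separate these two groups. For this pair, the number stays within the scatter without the acetyl and methoxy groups. Nothing available explains why the two groups read alike. From the compounds shown here alone, whether an unsubstituted phenoxy, a carboxylic acid or a longer chain would also stay within the scatter remains open.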